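The source may hold more compounds than are shown below. What is called first, only, known or untested is meant among the compounds shown, and "the series" means these compounds.

Working notes on the series. Compound 2 `COc1ccc(CNC(=O)CN2C(=O)/C(=C/c3ccc(-c4ccc(Cl)cc4)o3)SC2=S)cc1` gives 40000 nM in a functional assay on K562 cells (Homo sapiens) for cytotoxicity, read by MTT assay, with a stated time of 72 h; on this read-out higher numbers stand for weaker inhibition and lower numbers for stronger inhibition. Compound 3 `O=C(CN1C(=O)/C(=C/c2ccc(-c3ccc(Cl)cc3)o2)SC1=S)NCc1ccccc1Cl` gives 64000 nM in this assay, a step of a 1.6-fold higher number from compound 2 to compound 3 (0.20 log units; within the scatter). Compound 1 `N#Cc1cc(NC(=O)CN2C(=O)/C(=C/c3ccc(-c4ccc(Cl)cc4)o3)SC2=S)ccc1C(F)(F)F` reaches only a limit in this assay, > 250000 nM (the limit of > 250000 nM in this assay, at which 1 of the 3 values shown sits). The steps of an at least 6.2-fold lower number from compound 1 to compound 2 (0.79 log units; beyond the scatter) and an at least 3.9-fold lower number from compound 1 to compound 3 (0.59 log units; beyond the scatter) lie beyond the scatter. Compound 2 therefore holds the lowest of the two numbers shown, with compound 3 within the scatter of it. Compound 4 `CCCCCCNC(=O)CN1C(=O)/C(=C/c2ccc(-c3ccc(Cl)cc3)o2)SC1=S` differs from compound 2 by pentyl in place of 4-methoxyphenyl on a saturated chain carbon bound to an amide-type nitrogen. For the measured compounds named here, no measured step trades the aryl on that carbon for a chain; the only step on that carbon, 2-chlorophenyl for 4-methoxyphenyl, stayed within the scatter. For compound 4 a small step is expected in this assay, a 1.4-fold higher number from compound 2 to compound 4 (0.14 log units; within the scatter), likely none beyond the scatter. Compound 4 is estimated at 55000 nM, ranging from 15000 nM to 180000 nM.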

Compound 4, half-maximal inhibitory concentration: 50000 nM
Estimate against measurement, compound 4: 1.1-fold (0.04 log units) above; the measured number falls inside the stated range.
By their numbers in this assay, from the lowest: compounds 2, 4 and 3 (each within the scatter of the next). At a limit, above all of these: compound 1.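

In this assay, a chain on the saturated chain carbon bound to an amide-type nitrogen does as well as an aryl there: pentyl gives a 1.3-fold higher number from compound 2 to compound 4 (0.10 log units; within the scatter) and a 1.3-fold lower number from compound 3 to compound 4 (0.11 log units; within the scatter), so the aromatic ring on that carbon is not needed to hold the number within the scatter. Hexyl in place of 3-cyano-4-(trifluoromethyl)phenyl on the amide-type nitrogen gives an at least 5.0-fold lower number from compound 1 to compound 4 (0.69 log units; beyond the scatter). That step starts from a limit, not a number: the limit of > 250000 nM in this assay, at which 1 of the 4 values shown sits.

On these data alone, whether a longer chain, an amine or a carboxylic acid at this position would move the number beyond the scatter remains open.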